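This account rests on a few compounds, and the source may have more. Where it says the series, first, only, none or still open, it means among the compounds named here.

Working notes on the series in an assay on Sf9 cells for inhibition of histone deacetylase 11 (Homo sapiens), read by fluorescence, tested at 0.5 uM; on this read-out higher numbers stand for more inhibition at the one concentration tested (going by the name of the read-out) and lower numbers for less inhibition. Compound 3, of structure `O=C(NO)c1cccc(-c2cn([C@@H]3C[C@H](C(=O)O)N(CCCc4ccccc4)C3)nn2)c1`, gives in this assay only a limit of the assay, < 10%, so its place is known no more closely than that; this is the case described by the limit of < 10% in this assay, at which 2 of the 3 values shown sit. Compound 1, of structure `O=C(NO)c1cccc(-c2cn([C@H]3C[C@H](CO)N(CCCc4ccccc4)C3)nn2)c1`, also returns a limit in this assay, < 10%. Compound 2, of structure `O=C(/C=C/c1cn([C@@H]2C[C@H](CO)N(CCCc3ccccc3)C2)nn1)NO`, reaches 12% in this assay. That reading of compound 2 is not set apart from the readings of compound 1 and compound 3 by more than the usual scatter.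

Compound 4, of structure `O=C(NO)c1cccc(-c2cn([C@@H]3C[C@H](CO)N(CCCc4ccccc4)C3)nn2)c1`, differs from compound 3 by hydroxymethyl in place of carboxy on a saturated ring carbon. For the measured compounds named here, no measured pair in the set shows a change of this kind, so the size of the step cannot be taken from a comparable step; nothing seen in this assay rises clearly above the scatter, and no direction beyond it is expected for the step from carboxy to hydroxymethyl. The step of a number no lower from compound 3 to compound 4 (the limit leaves the size open) is therefore estimated as no more than scatter. Compound 4 is expected to give about 10%, in the range 3% to 22%, with a fair chance that only a limit is reported.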

Compound 4, a percentage reported as inhibition, at one concentration (the size of the read-out at that concentration, not a potency): < 10%
Compound 4 gave a limit, no number (the forecaster's own chance of this, stated with the estimate: 55%); the middle value sits exactly at the limit.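

Neither carboxy nor hydroxymethyl on this saturated ring carbon lifts a compound clear of the scatter in this assay, and the floor of the assay now holds most of the series: the limit of < 10% in this assay, at which 3 of the 4 values shown sit. The steps to compound 4 from compound 3 and from compound 1 cannot be read, as both ends of each are limits, and this leaves the effect of configuration alone unresolved: the fact that compounds 1 and 4 differ only in the configuration as drawn. For the compounds shown here, the one readable step, for 3-(hydroxycarbamoyl)phenyl in place of 2-(hydroxycarbamoyl)ethenyl, is a number at least 2 percentage points lower from compound 2 to compound 4 (that floor lies within the scatter).

Going by these compounds, whether an aminomethyl group on this ring carbon, or a longer chain in place of 3-phenylpropyl, would give a reading clear of the scatter stays open. Also open, on these data alone, is whether carboxy, hydroxymethyl and the two configurations differ at all beneath the limit.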